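From methoxy to chloro on a weak compound

The source may hold more compounds than are shown below. What is called first, only, known or untested is meant among the compounds shown, and "the series" means these compounds.

Compound 1 `COc1cccc(-c2ncnn2-c2cc(OC)c(OC)c(OC)c2)c1`: > 10000 nM
Compound 2 `COc1ccc(-n2ncnc2-c2cc(OC)c(OC)c(OC)c2)cc1`: 93 nM

In a functional assay on Jurkat cells (Homo sapiens) for antiproliferative activity, read by MTT assay, with a stated time of 72 h (a lower number here means a stronger inhibitor, a higher number a weaker inhibitor), compound 1 gives only a limit, > 10000 nM, rather than an exact number. Compound 2 gives a measured number, 93 nM. Compound 3 `COc1cc(-n2ncnc2-c2cccc(Cl)c2)cc(OC)c1OC` has not yet been measured. It keeps the core of compound 1 and changes one group, 3-methoxyphenyl to 3-chlorophenyl, which puts chloro in place of methoxy on an aromatic carbon. Going by the values given here, no measured pair of compounds shows what this change does, so the expectation starts from compound 1 and its limit of > 10000 nM. In this assay, a small gain in potency at best is expected, and compound 3 may well stay at the limit. The estimated change is an at least 1.4-fold lower number from compound 1 to compound 3 (0.15 log units; that floor lies within the scatter). Compound 3 is expected at 7000 nM, with an estimated range from 1500 nM to 10000 nM.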

Compound 3, half-maximal inhibitory concentration: > 10000 nM
Compound 3 ended at the assay's limit; the forecaster's own chance of this, stated with the estimate: 55%; middle value at least 1.4-fold (0.15 log units) from the limit.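

Going by these compounds alone, compound 1 and compound 3 each give only a limit, so no step between them can be read: the limit of > 10000 nM in this assay, at which 2 of the 3 values shown sit.
In this assay, from the compounds shown here alone, it stays open how far either compound lies past that limit, and whether chloro in place of methoxy changes potency at all.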